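The compounds below may be only part of what the source reports. "The series", "measured", "known", "first", "only" and "open" are said of these compounds alone.

In an ADME assay on isolated protein for inhibition of Amine oxidase [flavin-containing] A (Homo sapiens), read by fluorescence and Amplex Red, with stated times of 15 min and 20 min (a higher number here means a weaker inhibitor, a lower number a stronger inhibitor), three compounds have been measured so far. Compound 1 `C#CCN(CCCCOc1ccc2ccc(=O)oc2c1)Cc1ccc(OC)cc1` gives 54500 nM, compound 2 `C#CCN(CCCOc1ccc2ccc(=O)oc2c1)Cc1ccc(C)cc1` gives 116000 nM, and compound 3 `C#CCN(CCCCOc1ccc2ccc(=O)oc2c1)Cc1ccccc1` gives 89400 nM. Compound 2 has the highest of the three numbers: it sits within the scatter of the number for compound 3, and beyond the scatter of the number for compound 1, which lies lower. Compound 4 `C#CCN(CCCOc1ccc2ccc(=O)oc2c1)Cc1ccccc1` has not been measured yet. It differs from compound 2 in one place: hydrogen in place of methyl on an aromatic carbon. For the measured compounds named here, one measured step bears on this change, namely a 1.6-fold higher number from compound 1 to compound 3 (0.21 log units; within the scatter), where a methoxy group on the same kind of aromatic carbon was replaced by hydrogen, although in compounds 1 and 3 the chain between the amine and the shared core is longer than in compound 2. Compounds 2 and 3 differ in two places at once, so their two values can only be set side by side, not read as a single step. Removing a small group from that ring has so far shifted the half-maximal inhibitory concentration by less than the scatter, so for compound 4 no step beyond the scatter is expected in this assay. The step expected here is a 1.1-fold higher number from compound 2 to compound 4 (0.05 log units; within the scatter). Compound 4 is expected to give about 130000 nM, between 60000 nM and 280000 nM.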

Compound 4, half-maximal inhibitory concentration: 38600 nM
Beside the measured number, compound 4's estimate is 3.4-fold (0.53 log units) above it; measured number below the stated range.
By their numbers in this assay, from the lowest: compounds 4, 1, 3 and 2 (each within the scatter of the next, the first and the last beyond it).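

In this assay, for the compounds shown here, going from 4-methylbenzyl to benzyl gives a 3.0-fold lower number from compound 2 to compound 4 (0.48 log units; beyond the scatter), the first step at this aromatic carbon, para to a large group, that lies beyond the scatter. It shows that a change of a single carbon at this place can be read in this assay, whereas the earlier step, a 1.6-fold higher number from compound 1 to compound 3 (0.21 log units; within the scatter), with methoxy leaving on the longer chain, stayed within the scatter, so removing a small group from this carbon does not give one uniform result across the compounds shown. Nothing measured here explains why the two steps differ.

Methoxy and methyl each appear on only one chain length, so these compounds cannot separate the effect of the group from that of the chain, and compound 3 at 89400 nM and compound 4 at 38600 nM form the only pair that differs in chain length alone. As far as these compounds go, how a methoxy group on the shorter chain, a methyl group on the longer chain, or a different group at this carbon, such as chlorine, fluorine or ethyl, would read in this assay remains open.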